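The compounds below may be only part of what the source reports. "The series", "measured", "known", "first", "only" and "open" are said of these compounds alone.

Working notes on the series. Compound 1 `CCO[C@H]1CC[C@H]2CCN(C)[C@H]2C1` in an assay on HEK293 cells for displacement of a labelled ligand from Neuronal acetylcholine receptor; alpha4/beta4 (Rattus norvegicus), with a stated time of 4 h (a higher number here means a weaker inhibitor, a lower number a stronger inhibitor), is reported only as a limit, > 300000 nM, not a number. Compound 2 `COCCO[C@H]1CC[C@H]2CCN(C)[C@H]2C1` in this assay is likewise reported as a limit, > 300000 nM. The step from compound 1 to compound 2 is therefore unreadable: a step that the two limits leave unreadable from compound 1 to compound 2, both ends sitting at the limit of > 300000 nM in this assay, at which 2 of the 3 values shown sit. Going by the values given here, compound 3 `CO[C@H]1CC=C2CCN(C)[C@H]2C1` is the one member of the set with a number in this assay, compound 3 giving 100000 nM. The values of compound 1 and compound 2 are limits, so no ordering of compound 3 against either of them can be stated.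

Compound 4 `CCO[C@H]1CC=C2CCN(C)[C@H]2C1` differs from compound 3 by methyl in place of hydrogen on a saturated chain carbon bound to an oxygen on a saturated carbon. Among the compounds with values here, no measured step bears on a methyl-to-ethyl change on the core of compound 3; the only measured step, from compound 1 to compound 2, is unreadable and concerns a different change. The expectation for compound 4 in this assay is therefore a step no larger than the scatter, a 1.5-fold higher number from compound 3 to compound 4 (0.18 log units; within the scatter), with a real chance that only a limit is returned. Compound 4 is estimated at 150000 nM, between 50000 nM and 400000 nM.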

Compound 4, inhibition constant: > 300000 nM
Compound 4 was reported as a limit (the forecaster's own chance of this, stated with the estimate: 40%); middle value at least 2.0-fold (0.30 log units) from the limit.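

In this assay, going by these compounds alone, the change from methoxy to ethoxy on the core of compound 3 gives an at least 3.0-fold higher number from compound 3 to compound 4 (0.47 log units; beyond the scatter), the first readable step, though readable only as a lower bound. Within the data shown here, at this position, on a saturated chain carbon bound to an oxygen on a saturated carbon, the added methyl therefore costs binding measurably, which the earlier compounds could not show. Compound 3 remains the only compound with a number, and compound 4 is reported only as a limit: the limit of > 300000 nM in this assay, at which 3 of the 4 values shown sit.

As far as these compounds go, the full size of the step stays open, and every comparison between two limits cannot be read. Also open, from the compounds shown here alone, is whether a hydroxyl or an amine in place of the methoxy group would give a lower number than compound 3 in this assay.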